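Dipropylamino Replaces Iodophenylamino on a Shared Core

The source may report more compounds than this note shows. Statements on the series, on what has been measured and on what is new or still open speak of the compounds shown alone.

Compound 1, `O=C1C(Nc2ccc(I)cc2)=CC(=O)c2c1nc1n2[C@H]2OC[C@@H](O)[C@H]2OC1`: 4010 nM
Compound 2, `CCOc1ccccc1NC1=CC(=O)c2nc3n(c2C1=O)[C@H]1OC[C@@H](O)[C@H]1OC3`: 6040 nM
Compound 3, `Cc1ccc(NC2=CC(=O)c3nc4n(c3C2=O)[C@H]2OC[C@@H](O)[C@H]2OC4)cc1C`: 2690 nM

In a functional assay on HeLa cells (Homo sapiens) for inhibition, read by sulforhodamine B assay (a higher number here means a weaker inhibitor, a lower number a stronger inhibitor), compound 1 gives the second highest of the three numbers; compound 3 and compound 2 both lie within the scatter of it. For the measured compounds named here, the only measured step, a 2.2-fold lower number from compound 2 to compound 3 (0.35 log units; beyond the scatter), swaps one aromatic substituent for another. Compound 4, `CCCN(CCC)C1=CC(=O)c2c(nc3n2[C@H]2OC[C@@H](O)[C@H]2OC3)C1=O`, arises from compound 1 by dipropylamino in place of (4-iodophenyl)amino on a double-bonded ring carbon. Going by the values given here, no measured step touches a change of this kind, since all three measured compounds keep an aromatic ring on the amine nitrogen while compound 4 has none, and the modest aryl-to-aryl step offers little guide. A weakening step a 1.7-fold higher number from compound 1 to compound 4 (0.24 log units; within the scatter) is therefore expected, with wide uncertainty. Compound 4 is estimated at 7000 nM, within 2000 nM to 25000 nM.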

Compound 4, half-maximal inhibitory concentration: > 16000 nM
Compound 4 was reported as a limit (the forecaster's own chance of this, stated with the estimate: 15%); middle value at least 2.2-fold (0.35 log units) from the limit.
By their numbers in this assay, from the lowest: compounds 3, 1 and 2 (each within the scatter of the next, the first and the last beyond it). At a limit, above all of these: compound 4.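

In this assay, the value for compound 4, > 16000 nM, is a limit and not a number. Even so, the change gives an at least 3.9-fold higher number from compound 1 to compound 4 (0.60 log units; beyond the scatter), which shows that on this double-bonded ring carbon dipropylamino does not match (4-iodophenyl)amino, a departure from aromatic substitution on the amine nitrogen that the earlier aryl-to-aryl step could not test. The change removes the six-membered aromatic ring and the hydrogen-bond donor together.

Which of these two losses matters remains open. Propylamino, which retains the amine hydrogen without the ring, would help separate them.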